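From fluoro to chloro at compound 4

The source may hold more compounds than are shown below. What is called first, only, known or untested is meant among the compounds shown, and "the series" means these compounds.

In a physicochemical assay for solubility, in phosphate buffer, at pH 7.4 (on this read-out higher numbers stand for higher solubility and lower numbers for lower solubility), compound 1 (`CC(=O)N[C@@H]1CCC[C@H](C(=O)Nc2cc(-c3cnc4n3CCC4)c(Cl)cn2)C1`) stands at 490000 nM and compound 2 (`CC(=O)N[C@@H]1CCC[C@H](C(=O)Nc2cc(-c3cnn4c3OCCC4)c(Cl)cn2)C1`) at 110000 nM on the same scale. Compound 3 (`CC(=O)N[C@@H]1CCC[C@H](C(=O)Nc2cc(-c3cnn4c3CC(C)(C)C4)c(F)cn2)C1`) gives 550000 nM and so sits within the scatter of compound 1, while compound 2 lies lower, beyond the scatter.

The next compound, compound 4 (`CC(=O)N[C@@H]1CCC[C@H](C(=O)Nc2cc(-c3cnn4c3CC(C)(C)C4)c(Cl)cn2)C1`), departs from compound 3 in a single place: chloro in place of fluoro on an aromatic carbon with chloro in place of fluoro on an aromatic carbon and the rest of the structure unchanged.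

Among the measured compounds shown here, no measured pair isolates this swap. For the measured compounds named here, the only measured step, a 4.5-fold lower number from compound 1 to compound 2 (0.65 log units; beyond the scatter) and counted as modest, exchanges a different group and keeps chloro throughout, so it bears on the question only indirectly. It does show that chloro compounds in this small set can differ beyond the scatter, with compound 2 at 110000 nM and compound 1 at 490000 nM in this assay as the two readings.

The estimated change is a 1.6-fold lower number from compound 3 to compound 4 (0.20 log units; within the scatter) and this expected step stays within the scatter, with a slight lean downward. For compound 4 the estimated value is 350000 nM with an expected range from 120000 nM to 700000 nM as the working expectation.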

Compound 4, solubility: 150000 nM
Estimate against measurement, compound 4: 2.3-fold (0.37 log units) above; low and high end bracket the measured number.
By their numbers in this assay, from the lowest: compounds 2 and 4 (each within the scatter of the next); then compounds 1 and 3 (each within the scatter of the next).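

Among the compounds shown here, for chloro in place of fluoro on an aromatic carbon, the swap now has a direct reading in this assay: a 3.7-fold lower number from compound 3 to compound 4 (0.56 log units; beyond the scatter) is a modest step, and it comes with the rest of the structure unchanged, which no earlier pair offered. With chloro held constant, the group on the other aromatic carbon also looks different against this new compound, since a 3.3-fold lower number from compound 1 to compound 4 (0.51 log units; beyond the scatter) is likewise modest and beyond the scatter, whereas a 1.4-fold higher number from compound 2 to compound 4 (0.13 log units; within the scatter) stays within it, so compound 2 and compound 4 cannot be told apart on this read-out. Nothing available here accounts for any of these steps.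

For the compounds shown here, this single pair leaves open whether the same swap would give a similar step with the group of compound 1 or compound 2 in place, since it has been read with only one group attached. As far as these compounds go, how a methyl, a methoxy or a nitrile on that same aromatic carbon would compare with fluoro and chloro also stays open.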